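From Dimethylamino to Methoxy in a Growth Inhibitor

The source may report more compounds than this note shows. Statements on the series, on what has been measured and on what is new or still open speak of the compounds shown alone.

Measured so far in a functional assay on OVCAR-8 cells (Homo sapiens) for inhibition; a higher number here means a weaker inhibitor of growth, a lower number a stronger inhibitor of growth

Compound 1 `CN(C)c1ccc(NS(=O)(=O)c2c(F)c(F)c(F)c(F)c2F)cc1` gives 372 nM
Compound 2 `Cc1ccc(NS(=O)(=O)c2c(F)c(F)c(F)c(F)c2F)cc1C` gives 437 nM
Compound 3 `O=S(=O)(Nc1ccc2c(c1)OCCO2)c1c(F)c(F)c(F)c(F)c1F` gives 91 nM

Compound 1 stands within the scatter of compound 2, while compound 3 gives a clearly lower number than either. Compound 4 `COc1ccc(NS(=O)(=O)c2c(F)c(F)c(F)c(F)c2F)cc1` is still unmeasured. Going by the values given here, it has methoxy in place of dimethylamino on an aromatic carbon of the core of compound 1 methoxy in place of dimethylamino on an aromatic carbon and no measured pair isolates this change. A modest step toward a lower number, meaning stronger growth inhibition, is expected in this assay because compound 3 at 91 nM also bears oxygen on its aromatic ring. The expected change is a 2.2-fold lower number from compound 1 to compound 4 (0.34 log units; beyond the scatter) as estimated here. Compound 4 is estimated at 170 nM with 60 nM to 450 nM as its expected range.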

Compound 4, concentration for 50% growth inhibition: 50 nM
Compound 4: the middle estimate sits 3.4-fold (0.53 log units) above what was measured; the measured number lies below the stated range.
By their numbers in this assay, from the lowest: compounds 4 and 3 (each within the scatter of the next); then compounds 1 and 2 (each within the scatter of the next).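

In this assay, going by these compounds alone, the change to methoxy in place of dimethylamino on an aromatic carbon gives a 7.4-fold lower number from compound 1 to compound 4 (0.87 log units; beyond the scatter) and so provides the first single-place comparison in this set. It shows that the group at this position, para to a large group, can alter growth inhibition beyond the scatter while the rest of the core of compound 1 stays the same. No measurement shown here accounts for this step.

The compounds shown leave open how an ethoxy group, a hydroxyl group or a chlorine atom would behave at this position. They also leave open whether a primary amine here would track with dimethylamino or with methoxy.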